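This account rests on a few compounds, and the source may have more. Where it says the series, first, only, none or still open, it means among the compounds named here.

Measured compounds in hand:

Compound 1, `CN(C)C(=O)c1cc(-c2cnc(NCc3c(F)ccc4c3CCO4)c3cn[nH]c(=O)c23)n(C)n1`: 2.1
Compound 2, `O=C(Nc1cnc(NCc2c(F)ccc3c2CCO3)n2cnnc12)c1ccccc1`: 3
Compound 3, `CC(=O)N1CCC(c2cnc(NCc3c(F)ccc4c3CCO4)c3cn[nH]c(=O)c23)CC1`: 2.9

All three numbers come from a physicochemical assay for lipophilicity, using the shake flask method, in phosphate buffer, measured as octanol-water partition, with a stated time of 30 min, at pH 7.4; a higher number here means a more lipophilic compound, a lower number a more polar compound. Compound 2 sits at the top of the three values, but its gap to compound 3 lies within the scatter, so these two cannot be told apart; only its gap to compound 1 is beyond the scatter. Among the compounds with values here, the one step measured between neighbours that differ in a single place is a number 0.80 log units higher from compound 1 to compound 3 (beyond the scatter), and it concerns a different core and a different change.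

Compound 4, `Fc1ccc2c(c1CNc1ncc(Nc3ccccc3)c3nncn13)CCO2`, is compound 2 with one alteration: phenyl in place of benzoyl on a nitrogen on an aromatic ring. Within the data shown here, no measured pair shows this exact change, so the only guide is the size of the step from compound 1 to compound 3, which suggests that swapping one group for another of similar size on this scaffold moves this assay by a modest amount rather than a large one. The change sheds one hydrogen-bond acceptor and two heavy atoms, and on that basis a modest rise in this assay is expected rather than a fall. The expected step is a number 0.50 log units higher from compound 2 to compound 4 (beyond the scatter). For compound 4 the estimate is 3.5, in the range 2.9 to 4.1.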

Compound 4, distribution coefficient: 3.3
Compound 4: the middle estimate sits 0.20 log units above what was measured; measured number inside the range.
By their numbers in this assay, from the lowest: compound 1; then compounds 3, 2 and 4 (each within the scatter of the next, the first and the last beyond it).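

Replacing benzoyl with phenyl on a nitrogen on an aromatic ring, which turns benzamido into anilino, gives in this assay a number 0.30 log units higher from compound 2 to compound 4 (within the scatter) and so cannot be told apart from the spread of repeat measurements. Within the data shown here, this is the only measured pair at this position, and it shows that benzoyl, with 8 heavy atoms and 1 hydrogen-bond acceptor, can give way to phenyl, with 6 heavy atoms and 0 hydrogen-bond acceptors, without a step beyond the scatter in this assay on this core. No measurement at hand speaks to the reason for the size of this step.

One pair at one position leaves open how this assay would respond if the group on this nitrogen carried an amine, a carboxylic acid or a longer chain such as benzyl in place of phenyl. It also leaves open whether the change from benzoyl to phenyl would give a step of similar size on a different core.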